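Carbamate ester variation on the shared core

The source may report more compounds than this note shows. Statements on the series, on what has been measured and on what is new or still open speak of the compounds shown alone.

Among the compounds with values here, compound 2 `Cc1nc(S(C)(=O)=O)ccc1Oc1ncnc(OC2CCN(C(=O)OC(C)(C)C(F)(F)F)CC2)c1F` gives 6.53 nM in a functional assay on isolated protein for inhibition of Glucose-dependent insulinotropic receptor (Homo sapiens), read by HTRF and cAMP accumulation (a lower number here means that less compound is needed, a higher number that more compound is needed for the effect), the lowest of the two numbers so far. Within the data shown here, compound 1 `Cc1nc(S(C)(=O)=O)ccc1Oc1ncnc(OC2CCN(C(=O)OC3CCC3)CC2)c1F` gives 13.6 nM in this assay, and the only measured step, a 2.1-fold lower number from compound 1 to compound 2 (0.32 log units; beyond the scatter), shows a modest gain from exchanging the ring for an open-chain group. Compound 3 `Cc1nc(S(C)(=O)=O)ccc1Oc1ncnc(OC2CCN(C(=O)OC(C)(C)C#N)CC2)c1F` differs from compound 2 by cyano in place of trifluoromethyl on a saturated chain carbon bound to an oxygen next to a carbonyl group and two saturated chain carbons. Among the measured compounds shown here, no measured step covers this exchange; the one known step concerns the same position but replaces a different group, so it sets only the scale of what one change there has done. With nothing pointing in either direction beyond the scatter, the number for compound 3 is expected to stay close to that of compound 2, with a step of a 1.4-fold higher number from compound 2 to compound 3 (0.14 log units; within the scatter). For compound 3 the estimate in this assay is 9 nM, with a range from 3.5 nM to 24 nM.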

Compound 3, half-maximal effective concentration: 92.9 nM
Beside the measured number, compound 3's estimate is 10-fold (1.01 log units) below it; measured number outside the range, above it.
By their numbers in this assay, from the lowest: compound 2; then compound 1; then compound 3.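

In this assay, cyano in place of trifluoromethyl on a saturated chain carbon bound to an oxygen next to a carbonyl group and two saturated chain carbons gives a 14-fold higher number from compound 2 to compound 3 (1.15 log units; beyond the scatter), so this position can respond far more strongly than the earlier modest step suggested. The exchange of cyclobutyl for 1-cyano-1-methylethyl gives a 6.8-fold higher number from compound 1 to compound 3 (0.83 log units; beyond the scatter), so an open-chain group here does not by itself bring a lower number: compound 2 lies below compound 1, while compound 3 lies above it. Nothing measured here speaks to what lies behind these steps.

Open, from the compounds shown here alone, is where a plain methyl group in place of trifluoromethyl would fall relative to compound 2 and compound 3. Also open, going by these compounds, is how a methoxy group or a primary amine would behave on that same carbon.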